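A few compounds are considered here, and "the series" means these few. Any claim that something is new, unique, unknown or untested is made for them only; others in the source may bear on it.

Compound 1 `N=C(N)c1ccc2oc(-c3ccc(OCCCOc4ccccc4)cc3)cc2c1`: in an ADME assay on L6 cells (Rattus norvegicus) for cytotoxicity, read by resazurin assay, with a stated time of 70 h (a lower number here means a stronger inhibitor, a higher number a weaker inhibitor), compound 1 gives 7300 nM.
Compound 2 `N=C(N)c1ccc2oc(-c3ccc(OCCCCOc4ccccc4)cc3)cc2c1`: in this assay compound 2 gives 1300 nM.
Compound 3 `c1ccc(OCCCCOc2ccc(-c3cc4cc(C5=NCCN5)ccc4o3)cc2)cc1`: in this assay compound 3 gives 2900 nM.

Of the three numbers, compound 2 has the lowest; compound 3 stands nearest to it and compound 1 furthest, both gaps beyond the scatter. Compound 4 `N=C(N)c1ccc2oc(-c3ccc(OCCCCCOc4ccccc4)cc3)cc2c1` has not been measured. It differs from compound 2 by phenoxymethyl in place of phenoxy on a saturated chain carbon, four bonds along the chain from an oxygen on an aromatic ring. Going by the values given here, one measured step bears directly on this change: a 5.6-fold lower number from compound 1 to compound 2 (0.75 log units; beyond the scatter), which is the same exchange made three bonds along the chain from the aromatic oxygen. The step of a 2.2-fold higher number from compound 2 to compound 3 (0.35 log units; beyond the scatter) alters the other end of the shared core and does not inform the present change. With a single comparable step in hand, a further lowering of the number is expected, though of uncertain size, and the expected step is a 1.6-fold lower number from compound 2 to compound 4 (0.21 log units; within the scatter). Compound 4 is therefore estimated at 800 nM, with a range from 300 nM to 2500 nM.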

Compound 4, half-maximal inhibitory concentration: 4200 nM
For compound 4 the middle estimate is 5.3-fold (0.72 log units) below the measured one; the whole stated range lies below it.
By their numbers in this assay, from the lowest: compound 2; then compounds 3, 4 and 1 (each within the scatter of the next, the first and the last beyond it).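

In this assay the exchange of phenoxy for phenoxymethyl, made four bonds along the chain from an oxygen on an aromatic ring, runs the opposite way from the same exchange made three bonds along: a 3.2-fold higher number from compound 2 to compound 4 (0.51 log units; beyond the scatter) here, against a 5.6-fold lower number from compound 1 to compound 2 (0.75 log units; beyond the scatter) there. Compound 2 thus stands apart from both chain neighbours, while a 1.7-fold lower number from compound 1 to compound 4 (0.24 log units; within the scatter) does not separate compound 1 from compound 4. No data at hand account for this reversal.

The compounds shown leave open whether a longer chain on the same core would stay near compound 4 or shift the number again, and whether the reversal holds with the end group of compound 3 on the core. On these data alone, what an amine or a carboxylic acid at the far end of the chain would do also remains open.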